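This account rests on a few compounds, and the source may have more. Where it says the series, first, only, none or still open, it means among the compounds named here.

For the measured compounds named here, compound 2, with the structure `O=C(/C=C/c1ccc(Cl)cc1)NS(=O)(=O)c1ccccc1`, has the highest of the two numbers measured so far in a functional assay on B16-F10 cells (Mus musculus) for antiproliferative activity, read by ELISA and MTT assay, with a stated time of 48 h; a lower number here means a stronger inhibitor, a higher number a weaker inhibitor: compound 2 gives 2.2 ug/mL. Its nearest neighbour is compound 1, with the structure `O=C(/C=C/c1ccc(F)cc1)NS(=O)(=O)c1ccccc1`, which in this assay gives 2.1 ug/mL; the step of a 1.0-fold higher number from compound 1 to compound 2 (0.02 log units; within the scatter) lies within the scatter, so the two compounds cannot be placed in any order.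

The next compound, compound 3 with the structure `O=C(/C=C/c1ccc(Cl)cc1)NS(=O)(=O)c1ccc(Cl)cc1`, differs from compound 2 by chloro in place of hydrogen on an aromatic carbon. Going by the values given here, the only measured step that bears on this is the one from compound 1 to compound 2, a chloro in place of fluoro on an aromatic carbon, and it was a 1.0-fold higher number from compound 1 to compound 2 (0.02 log units; within the scatter). That step involved a different ring and a different kind of exchange, so it speaks only loosely to the present change; still, it gives no hint that a chloro on this core moves the number.

On that basis compound 3 is expected to show no change at the digits printed from compound 2 to compound 3 (within the scatter), that is, no shift beyond the scatter. The estimate for compound 3 in this assay is 2.2 ug/mL, within a range from 1.1 ug/mL to 4.4 ug/mL.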

Compound 3, half-maximal inhibitory concentration: 2.5 ug/mL
For compound 3 the middle estimate is 1.1-fold (0.06 log units) below the measured one; low and high end bracket the measured number.
By their numbers in this assay, from the lowest: compounds 1, 2 and 3 (each within the scatter of the next).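

In this assay, the change of phenyl to 4-chlorophenyl, on the aromatic ring that carries no halogen in compound 1 and compound 2, gives a 1.1-fold higher number from compound 2 to compound 3 (0.06 log units; within the scatter) and so does not separate the two compounds. For the compounds shown here, the earlier step only exchanged one halogen for another on the other ring, so this is the first reading at this place, and it shows that a chloro here, on an aromatic carbon para to a large group, leaves the number within the scatter of the unsubstituted compound 2. No accompanying measurement speaks to what lies behind this result.

Chloro is the only group shown at this place, so it remains open whether a fluoro, a methoxy, an amine or a carboxylic acid there would move the number beyond the scatter. Going by these compounds, all three compounds also share the amide hydrogen and the double bond, and it remains open what a methyl on that nitrogen or a saturated chain in place of the double bond would do to the number.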